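The compounds below may be only part of what the source reports. "The series", "measured", "known", "first", "only" and "open" are said of these compounds alone.

Working notes on the series. In a functional assay on HFF cells (Homo sapiens) for cytotoxicity (a higher number here means a weaker inhibitor, a lower number a stronger inhibitor), compound 1 `CCOC[C@H]1OC(n2c(Cl)nc3cc(Cl)c(Cl)cc32)[C@H](O)[C@@H]1O` gives 26000 nM and compound 2 `O[C@@H]1[C@@H](CBr)OC(n2c(Cl)nc3cc(Cl)c(Cl)cc32)[C@@H]1O` gives 32000 nM. The two values lie within the scatter of each other, so compound 2 stands level with compound 1 on the numbers available, and neither can be ranked.

The next structure is compound 3 `O[C@@H]1[C@@H](CI)OC(n2c(Cl)nc3cc(Cl)c(Cl)cc32)[C@@H]1O`, which keeps the shared core of compound 2 and changes one substituent: iodo in place of bromo on a saturated chain carbon bound to a saturated ring carbon. In words, this is iodo in place of bromo on a saturated chain carbon bound to a saturated ring carbon.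

For the measured compounds named here, only one measured step bears on this change. It sits at the same place, with bromo in place of ethoxy, and amounts to a 1.2-fold higher number from compound 1 to compound 2 (0.09 log units; within the scatter). Going by the values given here, that exchange of two quite different substituents left the read-out within the scatter, although a single step is thin evidence and no iodo compound has a measured value yet. No shift beyond the scatter is therefore expected in this assay, and no direction is favoured. The expected step is a 1.1-fold lower number from compound 2 to compound 3 (0.03 log units; within the scatter). For compound 3 the estimated value is 30000 nM, with an expected range of 13000 nM to 70000 nM.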

Compound 3, half-maximal inhibitory concentration: 32000 nM
Estimate against measurement, compound 3: 1.1-fold (0.03 log units) below, within the range that was stated.
By their numbers in this assay, from the lowest: compounds 1, 2 and 3 (each within the scatter of the next).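

In this assay the step between the two halogens on a saturated chain carbon bound to a saturated ring carbon reads no change at the digits printed from compound 2 to compound 3 (within the scatter) and so gives no ground for separating iodo from bromo at this place. The comparison with ethoxy reads a 1.2-fold higher number from compound 1 to compound 3 (0.09 log units; within the scatter) and adds a second, independent exchange of ethoxy for a halogen that stays within the scatter, so the earlier single step no longer stands alone, and ethoxy, bromo and iodo all stand level on the numbers available. Nothing available accounts for these level values.

The three groups compared leave open whether any substituent on this carbon can move the read-out beyond the scatter, and a free hydroxyl, an amine, a carboxylic acid or a longer chain there would each test that. Also open, as far as these compounds go, is whether the same level picture would hold for bromomethyl and iodomethyl if the shared core were changed elsewhere.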